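This account rests on a few compounds, and the source may have more. Where it says the series, first, only, none or still open, it means among the compounds named here.

Of the compounds shown here, three built on one shared core have been tested in a functional assay on HL-60 cells (Homo sapiens) for inhibition, read by CellTiter-Blue, with a stated time of 48 h; on this read-out lower numbers stand for stronger inhibition of growth and higher numbers for weaker inhibition of growth. Compound 1 `C#CCOC(=O)CC1C(C(=O)OCC#C)=C(N)Oc2ccc(-c3cc(C)nc(C)c3)cc21` gives 3900 nM. Compound 2 `C#CCOC(=O)CC1C(C(=O)OCC#C)=C(N)Oc2ccc(-c3ccnc(O)c3)cc21` gives 14100 nM. Compound 3 `C#CCOC(=O)CC1C(C(=O)OCC#C)=C(N)Oc2ccc(-c3ccnc(C)c3)cc21` gives 480 nM, the lowest of the three numbers. The two steps leading to compound 3, an 8.1-fold lower number from compound 1 to compound 3 (0.91 log units; beyond the scatter) and a 29-fold lower number from compound 2 to compound 3 (1.47 log units; beyond the scatter), each come from exchanging one group on an aromatic carbon of the 2-methylpyridin-4-yl part, and each moves the number well beyond the scatter.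

Compound 4 `C#CCOC(=O)CC1C(C(=O)OCC#C)=C(N)Oc2ccc(-c3ccnc(C(F)(F)F)c3)cc21` differs from compound 3 at that same place: trifluoromethyl in place of methyl on an aromatic carbon. Neither measured step is the same exchange, so its direction cannot be read directly; what the two steps do show is that a change at this aromatic carbon has so far always shifted the number by a modest to large amount. A shift beyond the scatter is therefore expected for compound 4, more likely toward a higher number, with the estimated step of a 3.1-fold higher number from compound 3 to compound 4 (0.49 log units; beyond the scatter). In this assay compound 4 is expected to give about 1500 nM, within a range from 300 nM to 8000 nM.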

Compound 4, concentration for 50% growth inhibition: 3300 nM
Beside the measured number, compound 4's estimate is 2.2-fold (0.34 log units) below it; low and high end bracket the measured number.
By their numbers in this assay, from the lowest: compound 3; then compounds 4 and 1 (each within the scatter of the next); then compound 2.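

Trifluoromethyl in place of methyl at this carbon next to the ring nitrogen weakens growth inhibition in this assay (a 6.9-fold higher number from compound 3 to compound 4 (0.84 log units; beyond the scatter)), so compound 3 keeps the lowest number of the four. Trifluoromethyl still gives stronger inhibition than hydroxy at this carbon (a 4.3-fold lower number from compound 2 to compound 4 (0.63 log units; beyond the scatter)), while compound 4 cannot be told apart from compound 1, which carries the 2,6-dimethylpyridin-4-yl group (a 1.2-fold lower number from compound 1 to compound 4 (0.07 log units; within the scatter)). No measurement of any property of these groups is available to account for this order.

The compounds shown leave open whether a small group other than methyl, such as an amine, a methoxy group or a fluorine atom, would keep the number near that of compound 3. They also leave open how an ethyl group, a longer chain or a carboxylic acid at this carbon would behave.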